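Amine swap on the thiophene-fused series against the hormone receptor

The source may report more compounds than this note shows. Statements on the series, on what has been measured and on what is new or still open speak of the compounds shown alone.

Compound 3 `O=c1c2sc(-c3ccc(Cl)cc3)cc2ncn1-c1ccc2sc(CN3CCCC3)cc2c1` gives 0.91 nM in a functional assay on CHO cells for antagonist activity at melanin-concentrating hormone receptor 1 (Homo sapiens), read by reporter gene assay (on this read-out lower numbers stand for stronger inhibition and higher numbers for weaker inhibition), the lowest of the three numbers, though its gaps to compound 1 `CN(C)CC1CCc2cc(-n3cnc4cc(-c5ccc(Cl)cc5)sc4c3=O)ccc2C1`, which gives 1.1 nM, and to compound 2 `O=c1c2sc(-c3ccc(Cl)cc3)cc2ncn1-c1ccc2c(c1)CCC(CN1CCCC1)C2`, which gives 1.3 nM, are both within the scatter. Among the compounds with values here, the one measured step that bears on an amine exchange is a 1.2-fold higher number from compound 1 to compound 2 (0.07 log units; within the scatter), where one cyclic amine replaced a dialkylamine without effect. Compound 4 `CN1CCN(Cc2cc3cc(-n4cnc5cc(-c6ccc(Cl)cc6)sc5c4=O)ccc3s2)CC1` carries 4-methylpiperazin-1-yl in place of pyrrolidin-1-yl on a saturated chain carbon bound to an aromatic carbon. Within the data shown here, no measured step covers this exact exchange, so the expectation rests on the indifference seen in this assay from compound 1 to compound 2: the step is expected to be a 1.6-fold higher number from compound 3 to compound 4 (0.22 log units; within the scatter). Compound 4 is therefore estimated at 1.5 nM, between 0.5 nM and 4.5 nM.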

Compound 4, half-maximal inhibitory concentration: 9.7 nM
Beside the measured number, compound 4's estimate is 6.5-fold (0.81 log units) below it, outside the stated range (above it).
By their numbers in this assay, from the lowest: compounds 3, 1 and 2 (each within the scatter of the next); then compound 4.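

In this assay, the amine on a saturated chain carbon bound to an aromatic carbon is not freely exchangeable: 4-methylpiperazin-1-yl in place of pyrrolidin-1-yl gives an 11-fold higher number from compound 3 to compound 4 (1.03 log units; beyond the scatter) and so lies beyond the scatter. The earlier exchange, a 1.2-fold higher number from compound 1 to compound 2 (0.07 log units; within the scatter), stayed within the scatter, but that indifference does not carry over to this change. Nothing given here accounts for the rise.

The compounds shown do not separate the effect of the ring's second nitrogen from that of its methyl. Going by these compounds, how piperazin-1-yl, piperidin-1-yl or morpholin-4-yl would behave at this place remains open.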